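A Carbamoyl-to-Aminoethyl Swap on the Shared Core

A few compounds are considered here, and "the series" means these few. Any claim that something is new, unique, unknown or untested is made for them only; others in the source may bear on it.

Of the compounds shown here, three built on one shared core have been tested in a functional assay (Oryctolagus cuniculus) for antagonist activity at platelet-activating factor receptor (Cavia porcellus); on this read-out higher numbers stand for weaker inhibition and lower numbers for stronger inhibition. Compound 1 `CN(C)C(=O)n1cc(C(=O)c2ccn3c2CSC3c2cccnc2)c2ccc(-c3ccccc3)cc21` gives 23 nM. Compound 2 `CC(C)(C)OC(=O)n1cc(C(=O)c2ccn3c2CSC3c2cccnc2)c2ccccc21` gives 110 nM in this assay. For the measured compounds named here, compound 3 `CCNC(=O)n1cc(C(=O)c2ccn3c2CSC3c2cccnc2)c2ccc(-c3ccc(F)cc3)cc21` gives 19 nM; this number and the one from compound 1 lie within the usual scatter of each other, while the number from compound 2 stands apart from both and is higher.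

Compound 4 `NCCn1cc(C(=O)c2ccn3c2CSC3c2cccnc2)c2ccc(-c3ccc(F)cc3)cc21` has not yet been measured. It differs from compound 3 in a single place: 2-aminoethyl in place of ethylcarbamoyl on an aromatic nitrogen, in words 2-aminoethyl in place of ethylcarbamoyl on an aromatic nitrogen. Going by the values given here, no measured pair here shows a change of this kind, so nothing in the numbers anchors the size of the step. Among the compounds with values here, every measured compound carries a carbonyl-bearing group on that nitrogen, and compound 4 is the first without one. The expected outcome is a weakening beyond the scatter, a step from compound 3 to compound 4 of a 4.2-fold higher number from compound 3 to compound 4 (0.62 log units; beyond the scatter). Compound 4 is therefore estimated at 80 nM, with a range from 15 nM to 400 nM.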

Compound 4, inhibition constant: 38 nM
Compound 4: the middle estimate sits 2.1-fold (0.32 log units) above what was measured, and the stated range covers the measured number.
By their numbers in this assay, from the lowest: compounds 3, 1 and 4 (each within the scatter of the next); then compound 2.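

In this assay, putting 2-aminoethyl in place of ethylcarbamoyl on the aromatic nitrogen gives a 2.0-fold higher number from compound 3 to compound 4 (0.30 log units; within the scatter) and so leaves the number within the usual scatter. Every earlier compound carries a carbonyl-bearing group on this nitrogen, so they could not show whether that carbonyl is needed; compound 4 has none and still stays level with compound 3 within that scatter. Nothing measured here explains why these two different groups give such similar numbers.

As far as these compounds go, it remains open whether the amine of the new chain matters, since a 2-hydroxyethyl group or a plain ethyl group on the same nitrogen would be needed to test that. From the compounds shown here alone, the effect of chain length also stays open, and a 3-aminopropyl chain or a carboxylic acid at the end of the chain could begin to answer it.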